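Fluoro for Methoxy: One Change Repeated on Two Cores

The compounds below may be only part of what the source reports. "The series", "measured", "known", "first", "only" and "open" are said of these compounds alone.

Measured compounds:
compound 1 `COc1cccc(OC(=O)c2ccccc2O)c1OC(=O)c1ccccc1O` gives 50.5%
compound 2 `O=C(Oc1cccc(F)c1OC(=O)c1ccccc1O)c1ccccc1O` gives 51%
compound 3 `COc1cc(C(=O)Oc2cccc(OC)c2OC(=O)c2cc(OC)c(OC)c(OC)c2)cc(OC)c1OC` gives 33.3%

All three were tested in a functional assay on NCI-H1299 cells (Homo sapiens) for inhibition, read by scintillation counting, with a stated time of 30 min, tested at 30 uM; a lower number here means less inhibition, a higher number more inhibition at the concentration tested (going by the name of the read-out). Compound 1 and compound 2 share a core and differ in one place, (fluoro in place of methoxy on an aromatic carbon); the step of a number 0.5 percentage points higher from compound 1 to compound 2 (within the scatter). Compound 3 sits on a different core; how its core differs from that of compound 1 is not broken down here. In this assay compound 3 shows the lowest of the three numbers, and both compound 1 and compound 2 stand beyond the scatter above it.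

Compound 4 `COc1cc(C(=O)Oc2cccc(F)c2OC(=O)c2cc(OC)c(OC)c(OC)c2)cc(OC)c1OC` is not yet measured. It differs from compound 3 by fluoro in place of methoxy on an aromatic carbon, the same change, at the same kind of place, that separates compound 1 from compound 2. Since that earlier step stayed within the scatter, the step from compound 3 to compound 4 is expected to be of similar size, a number 0.7 percentage points higher from compound 3 to compound 4 (within the scatter). Compound 4 is therefore estimated to give 34% in this assay, most likely between 22% and 46%.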

Compound 4, a percentage reported as inhibition, at one concentration (the size of the read-out at that concentration, not a potency): 7.9%
The estimate for compound 4 lay 26.1 percentage points above the measured number, and the stated range ends above it.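

In this assay, fluoro in place of methoxy on an aromatic carbon gives a number 25.4 percentage points lower from compound 3 to compound 4 (beyond the scatter), so the change does not behave alike on the two cores: the same change on two cores in this assay, a number 0.5 percentage points higher (within the scatter) from compound 1 to compound 2 and a number 25.4 percentage points lower (beyond the scatter) from compound 3 to compound 4, 25.9 percentage points apart, beyond the scatter of two such steps

This shows that, among these four compounds, the small step seen on the core of compound 1 cannot be taken as a guide to the step on the core of compound 3. It does not show why the two cores part ways, and two pairs, each read at a single concentration, give neither a measure of potency nor a rule for any further core in the series.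

The compounds shown leave open whether the low number of compound 4 belongs to fluoro itself or to the loss of methoxy from that place. They also leave open how a chloro group or an amine at the same place would read on either core.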